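Two Methyl Groups Added to a Cytotoxicity Non-Hit

The compounds below may be only part of what the source reports. "The series", "measured", "known", "first", "only" and "open" are said of these compounds alone.

Compound 1 `COc1ccc(/C=C2\S/C(=N\c3ccccc3)N(C)C2=O)cc1` — in an ADME assay on TERT-RPE1 cells (Homo sapiens) for cytotoxicity, read by MTT assay, with a stated time of 72 h (on this read-out lower numbers stand for stronger inhibition and higher numbers for weaker inhibition), compound 1 gives > 100000 nM, a limit of the assay rather than a number.
Compound 2 `FC(F)(F)c1cc(/N=C2/NC/C(=C/c3ccccc3)S2)cc(C(F)(F)F)c1` — in this assay compound 2 gives 32800 nM.

Compound 1 stands at the limit of > 100000 nM in this assay, at which 1 of the 2 values shown sits, so no number is known for it. Among the measured compounds shown here, no step between compound 1 and compound 2 is counted here; their two values show only a number beside a limit. Compound 3 `COc1ccc(/C=C2\S/C(=N\c3c(C)cccc3C)N(C)C2=O)cc1` differs from compound 1 by 2,6-dimethylphenyl in place of phenyl on a double-bonded nitrogen. For the measured compounds named here, with no measured step of this kind, the change is expected to move this assay by no more than the scatter, in no clear direction. Compound 3 is therefore expected to give 100000 nM, between 40000 nM and 300000 nM. The expected step of a number no higher from compound 1 to compound 3 (the limit leaves the size open) is small, and a limit is again the likely report.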

Compound 3, half-maximal inhibitory concentration: > 100000 nM
Compound 3 gave a limit, no number; the forecaster's own chance of this, stated with the estimate: 70%; the middle value lies on the limit itself.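

Among the compounds shown here, compound 1 and compound 3 each give only a limit in this assay, not a number, so no step between them can be read. As far as these compounds go, whether 2,6-dimethylphenyl in place of phenyl shifts the cytotoxicity at all, and in which direction, stays open.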